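A few compounds are considered here, and "the series" means these few. Any claim that something is new, unique, unknown or untested is made for them only; others in the source may bear on it.

In a functional assay on MIA PaCa-2 cells (Homo sapiens) for antiproliferative activity, read by MTT assay, with a stated time of 24 h (on this read-out higher numbers stand for weaker inhibition and lower numbers for stronger inhibition), compound 1 `COc1ccc(-c2noc(-c3ccccc3)n2)cc1OC1CCCC1` reports only a limit of the assay, > 1000000 nM. Compound 2 `COc1ccc(-c2noc(-c3ccncc3)n2)cc1OC1CCCC1` gives 9330 nM, and compound 3 `COc1ccc(-c2noc(C3CCCN3)n2)cc1OC1CCCC1` gives 19500 nM, the higher of the two actual numbers. Compound 4 `COc1ccc(-c2noc(C3CCNCC3)n2)cc1OC1CCCC1` carries piperidin-4-yl in place of pyrrolidin-2-yl on an aromatic carbon of the shared core: piperidin-4-yl in place of pyrrolidin-2-yl on an aromatic carbon. The two large steps, an at least 100-fold lower number from compound 1 to compound 2 (2.03 log units; beyond the scatter) and an at least 51-fold lower number from compound 1 to compound 3 (1.70 log units; beyond the scatter), both replace phenyl, which this change does not do. The closer guide is the modest step of a 2.1-fold higher number from compound 2 to compound 3 (0.32 log units; beyond the scatter), which leads to compound 3 from another nitrogen-containing group. A similarly modest step with no firm direction is therefore expected, and the estimate is a 1.4-fold lower number from compound 3 to compound 4 (0.14 log units; within the scatter). For compound 4, the expected value is 14000 nM, within a range of 5000 nM to 45000 nM.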

Compound 4, half-maximal inhibitory concentration: 540 nM
The estimate for compound 4 lay 26-fold (1.41 log units) above the measured number, outside the stated range (below it).
By their numbers in this assay, from the lowest: compound 4; then compound 2; then compound 3. At a limit, above all of these: compound 1.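

In this assay, this position clearly tells two saturated nitrogen rings apart: piperidin-4-yl in place of pyrrolidin-2-yl gives a 36-fold lower number from compound 3 to compound 4 (1.56 log units; beyond the scatter), so a ring nitrogen alone does not set the activity. Piperidin-4-yl also outperforms the aromatic pyridin-4-yl, with a 17-fold lower number from compound 2 to compound 4 (1.24 log units; beyond the scatter). Against phenyl, the step of an at least 1800-fold lower number from compound 1 to compound 4 (3.26 log units; beyond the scatter) is only a minimum, since compound 1 gives a limit and not a number: the limit of > 1000000 nM in this assay, at which 1 of the 4 values shown sits.

Ring size and the place of attachment change together here, so the compounds shown cannot separate them. Piperidin-3-yl would address that question, and a piperidin-4-yl carrying a methyl group on its nitrogen would show whether the hydrogen on that nitrogen matters.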